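Swapping the aryl group on a piperazine ring

The compounds below may be only part of what the source reports. "The series", "measured", "known", "first", "only" and "open" are said of these compounds alone.

Measured so far:
compound 1, `S=C(SCc1nc2cc(Cl)c(Cl)cc2[nH]1)N1CCOCC1`, 5700 nM
compound 2, `CCOc1ccccc1N1CCN(C(=S)SCc2nc3cc(Cl)c(Cl)cc3[nH]2)CC1`, 16200 nM

Of the compounds shown here, two have been tested in a functional assay on MCF7 cells (Homo sapiens) for cytotoxicity, read by MTT assay, with a stated time of 24 h; a higher number here means a weaker inhibitor, a lower number a stronger inhibitor. Compound 1 gives 5700 nM in this assay, and compound 2 gives 16200 nM, the higher of the two numbers and beyond the usual scatter apart from compound 1. Compound 2 therefore stands as the weaker of the two measured compounds.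

Compound 3, `COc1ccc(N2CCN(C(=S)SCc3nc4cc(Cl)c(Cl)cc4[nH]3)CC2)cc1`, is not yet measured. It differs from compound 2 in one place: 4-methoxyphenyl in place of 2-ethoxyphenyl on an amine nitrogen in a ring. For the measured compounds named here, no measured pair shows the effect of such a swap, so the direction of the step is open. The most reasonable expectation is a step from compound 2 to compound 3 that stays within the scatter, a 1.2-fold lower number from compound 2 to compound 3 (0.06 log units; within the scatter). Compound 3 is expected to give about 14000 nM in this assay, with a likely range from 6000 nM to 35000 nM.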

Compound 3, half-maximal inhibitory concentration: 19900 nM
Beside the measured number, compound 3's estimate is 1.4-fold (0.15 log units) below it, and the stated range covers the measured number.
By their numbers in this assay, from the lowest: compound 1; then compounds 2 and 3 (each within the scatter of the next).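

In this assay the swap of 2-ethoxyphenyl for 4-methoxyphenyl on an amine nitrogen in a ring gives a 1.2-fold higher number from compound 2 to compound 3 (0.09 log units; within the scatter) and so no real difference between the two compounds. Both the ether chain and its numbered place on the phenyl ring differ in this swap, yet the two aryl groups cannot be told apart here. Nothing available explains this result.

Since both features differ at once, this single pair cannot show what each does alone, or whether their effects cancel. It also leaves open whether a phenyl ring carrying a carboxylic acid or an amine, or a longer chain on the oxygen, would give a number clearly apart from those of compound 2 and compound 3.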